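The compounds below may be only part of what the source reports. "The series", "measured", "known", "first", "only" and "open" are said of these compounds alone.

Of the compounds shown here, three have so far been measured in a functional assay on HeLa cells (Homo sapiens) for inhibition, read by CCK-8 assay, with a stated time of 48 h; a lower number here means a stronger inhibitor, a higher number a weaker inhibitor. Compound 1 `COc1ccc(-c2cc3nccc(-c4cc(OC)c(OC)c(OC)c4)n3n2)cc1N` gives 283 nM, compound 2 `COc1cc(-c2ccnc3cc(-c4c[nH]c5ccccc45)nn23)cc(OC)c1OC` gives 195 nM, and compound 3 `COc1cc(-c2ccnc3cc(-c4ccc(-c5cnn(C)c5)cc4)nn23)cc(OC)c1OC` gives 1830 nM. For the measured compounds named here, the only single-point step among them, a 1.5-fold lower number from compound 1 to compound 2 (0.16 log units; within the scatter), shows that exchanging one single-ring group for another on the shared core leaves the number essentially unchanged. Compound 3 stands at the highest number of the three, with compound 1 the nearest and compound 2 the furthest, and both gaps are beyond the scatter.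

Compound 4 `COc1cc(-c2ccnc3cc(-c4ccccc4)nn23)cc(OC)c1OC` is not yet measured. It differs from compound 3 by hydrogen in place of 1-methyl-1H-pyrazol-4-yl on an aromatic carbon. Going by the values given here, no measured step involves a 1-methyl-1H-pyrazol-4-yl, so the evidence is indirect. Among the compounds with values here, compounds 1 and 2, which each carry a single-ring group at this part of the molecule, both sit well below compound 3, while the one measured step, lying within the scatter, suggests that the exact identity of that single-ring group matters little. Within the data shown here, a downward move of a 3.1-fold lower number from compound 3 to compound 4 (0.48 log units; beyond the scatter) is therefore expected, though with real uncertainty, since no measured pair isolates this particular change. Compound 4 is estimated at 600 nM, with a range from 200 nM to 1800 nM.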

Compound 4, half-maximal inhibitory concentration: 458 nM
Beside the measured number, compound 4's estimate is 1.3-fold (0.12 log units) above it; the range from low to high includes it.
By their numbers in this assay, from the lowest: compounds 2, 1 and 4 (each within the scatter of the next, the first and the last beyond it); then compound 3.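

In this assay, for the compounds shown here, replacing the 1-methyl-1H-pyrazol-4-yl with hydrogen gives a 4.0-fold lower number from compound 3 to compound 4 (0.60 log units; beyond the scatter), the first direct reading of this change: on this six-membered aromatic ring, the plain phenyl gives a lower number than the phenyl carrying that large group. Compound 4 also provides an unsubstituted reference for the other groups, and the comparison shows a 2.3-fold higher number from compound 2 to compound 4 (0.37 log units; beyond the scatter), so the 1H-indol-3-yl and phenyl can be told apart, whereas a 1.6-fold higher number from compound 1 to compound 4 (0.21 log units; within the scatter) leaves 3-amino-4-methoxyphenyl and plain phenyl not separated. Nothing available explains why these numbers differ.

On these data alone, it remains open whether the higher number of compound 3 belongs to the 1-methyl-1H-pyrazol-4-yl in particular or would also come with another group at this place, such as a fluorine, a carboxylic acid or a morpholine. As far as these compounds go, the methoxy groups common to all four compounds never vary, so their contribution to the numbers also remains unknown.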